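The source may report more compounds than this note shows. Statements on the series, on what has been measured and on what is new or still open speak of the compounds shown alone.

Measured so far:
compound 1 `Nc1c(Br)cc(Br)cc1/C=C(\C(=O)c1ccc(Br)cc1)S(=O)(=O)c1ccc(Br)cc1` — in a functional assay on DU-145 cells (Homo sapiens) for inhibition, read by trypan blue exclusion, with a stated time of 96 h (on this read-out higher numbers stand for weaker inhibition of growth and lower numbers for stronger inhibition of growth), compound 1 gives 25000 nM
compound 2 `O=C(O)c1cc(/C=C(\C(=O)c2c(F)c(F)c(F)c(F)c2F)S(=O)(=O)c2ccc(Br)cc2)ccc1O` — in this assay compound 2 reaches only a limit of the assay, > 100000 nM

Among the compounds with values here, compound 1 therefore stands as the sole numerical value in the set; the other entry is a limit, (the limit of > 100000 nM in this assay, at which 1 of the 2 values shown sits). Compound 3 `COc1ccc(/C=C(\C(=O)c2ccc(Br)cc2)S(=O)(=O)c2ccc(Br)cc2)cc1` differs from compound 1 by 4-methoxyphenyl in place of 2-amino-3,5-dibromophenyl on a double-bonded chain carbon bound to a double-bonded chain carbon. Within the data shown here, no measured pair changes in exactly this place, so no step size is on hand. The change is expected to stay within the scatter or to move slightly weaker, the step being estimated as a 1.2-fold higher number from compound 1 to compound 3 (0.08 log units; within the scatter). Compound 3 is thus expected near 30000 nM, with a range of 8000 nM to 100000 nM.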

Compound 3, concentration for 50% growth inhibition: 25000 nM
Beside the measured number, compound 3's estimate is 1.2-fold (0.08 log units) above it; the range from low to high includes it.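

In this assay, within the data shown here, 4-methoxyphenyl in place of 2-amino-3,5-dibromophenyl gives no change at the digits printed from compound 1 to compound 3 (within the scatter), the first step that can be read at this position. The exchange removes the amine and both bromines and adds a methoxy group, yet the read-out does not separate the two groups. No measurement shown bears on why this step is flat.

As far as these compounds go, whether any single substituent on this ring matters remains open. An unsubstituted phenyl or a longer alkyl chain at this place would test how far the position responds at all.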